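Nitro in place of chloro: compound 2 to compound 4

A few compounds are considered here, and "the series" means these few. Any claim that something is new, unique, unknown or untested is made for them only; others in the source may bear on it.

Compound 2 `COc1ccc(-c2nnsc2SCC(=O)Nc2ccccc2Cl)cc1` stands only at a limit in an ADME assay on MT4 cells (Homo sapiens) for cytotoxicity; a lower number here means that less compound is tolerated, a higher number that more compound is tolerated: compound 2 gives > 318000 nM, which is a limit of the assay and not a number. The two other values shown are limits as well. Compound 1 `O=C(CSc1snnc1-c1ccccc1)Nc1ccccc1Cl` gives > 345000 nM, again a limit. Compound 3 `O=C(CSc1snnc1-c1ccccc1)Nc1ccccc1Br` gives > 307000 nM, also a limit. Each of the three values sits on its own limit, (the limit of > 307000 nM in this assay, at which 1 of the 3 values shown sits), the limit of > 318000 nM in this assay, at which 1 of the 3 values shown sits, and (the limit of > 345000 nM in this assay, at which 1 of the 3 values shown sits), so the steps a step that the two limits leave unreadable from compound 1 to compound 2 and a step that the two limits leave unreadable from compound 1 to compound 3 cannot be read in size or direction.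

Compound 4 `COc1ccc(-c2nnsc2SCC(=O)Nc2ccccc2[N+](=O)[O-])cc1` differs from compound 2 by nitro in place of chloro on an aromatic carbon. Within the data shown here, no measured step touches a nitro, and no measured step in this assay has a readable size, so there is nothing to set a direction. The step from compound 2 to compound 4 is expected to be an at least 1.0-fold lower number from compound 2 to compound 4 (0.02 log units; that floor lies within the scatter), that is no step beyond the scatter. Compound 4 is therefore expected at 300000 nM, within 100000 nM to 900000 nM, most likely reported again only as a limit.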

Compound 4, half-maximal cytotoxic concentration: >= 280000 nM
Compound 4: a limit, no number (the forecaster's own chance of this, stated with the estimate: 80%); the middle value does not contradict the limit.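

In this assay compound 4 gives >= 280000 nM, a limit and not a number. Compound 2 gives > 318000 nM, also a limit. Among these compounds, no step between compound 2 and compound 4 can be read. The compounds shown leave open whether nitro in place of chloro changes the tolerated concentration at all.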